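Replacing the Thioether Acid with a Branched Propanoic Acid

A few compounds are considered here, and "the series" means these few. Any claim that something is new, unique, unknown or untested is made for them only; others in the source may bear on it.

In a functional assay on CHO cells for agonist activity at Free fatty acid receptor 1 (Homo sapiens) (on this read-out higher numbers stand for an effect only at larger amounts of compound and lower numbers for an effect already at smaller amounts), compound 2 `O=C(O)CSc1ccc(NCc2cccc(Oc3ccccc3)c2)cc1` gives 324 nM, the higher of the two plain numbers in this set, and its nearest neighbour is compound 1 `O=C(O)/C=C/c1ccc(NCc2cccc(Oc3ccccc3)c2)cc1`, which gives 145 nM. Among the compounds with values here, the step of a 2.2-fold higher number from compound 1 to compound 2 (0.35 log units; beyond the scatter) is the only measured change at this aromatic carbon with a single number at each end. Within the data shown here, compound 3 `O=C(O)[C@H]1C[C@@H]1c1ccc(NCc2cccc(Oc3ccccc3)c2)cc1` gives 12.3 nM; 13.5 nM (2 entries), and the repeated entries the several entries of compound 3 in this assay, 12.3 nM; 13.5 nM (2 entries) show that this low number holds up; no single step links compound 3 to compound 2, so the two values are simply set side by side. Compound 4 `CC(Cc1ccc(NCc2cccc(Oc3ccccc3)c2)cc1)C(=O)O` differs from compound 2 by 2-carboxypropyl in place of (carboxymethyl)sulfanyl on an aromatic carbon. The measured exchange of one acid-bearing chain for another moved the number modestly, and a carbon-based acid chain on this core, as in compound 3, stands well below compound 2. A step of moderate size toward a lower number is therefore expected. Compound 4 is expected to give 60 nM, within 15 nM to 250 nM. That estimate means an expected step of a 5.4-fold lower number from compound 2 to compound 4 (0.73 log units; beyond the scatter).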

Compound 4, half-maximal effective concentration: 100 nM
Estimate against measurement, compound 4: 1.7-fold (0.22 log units) below, within the range that was stated.
By their numbers in this assay, from the lowest: compounds 4 and 1 (each within the scatter of the next); then compound 2.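

In this assay, putting 2-carboxypropyl in place of (carboxymethyl)sulfanyl on this aromatic carbon gives a change beyond the scatter (a 3.2-fold lower number from compound 2 to compound 4 (0.51 log units; beyond the scatter)), so among the compounds shown, compound 2 with its sulfur-linked chain stands above both compound 1 and compound 4. The saturated, branched chain and the 2-carboxyethenyl chain cannot be told apart (a 1.5-fold lower number from compound 1 to compound 4 (0.16 log units; within the scatter)), and only the ring-bearing acid of compound 3 stands clearly lower by its printed value (12.3 nM; 13.5 nM (2 entries)). Nothing measured here accounts for these differences between the chains.

The compounds shown leave open whether the methyl branch of 2-carboxypropyl matters, which an unbranched 2-carboxyethyl chain would address. They also leave open whether an oxygen-linked carboxymethoxy chain would stand with compound 2 or with compound 4.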